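From an Amide Arm Back to a Haloaryl Group

The source may hold more compounds than are shown below. What is called first, only, known or untested is meant among the compounds shown, and "the series" means these compounds.

Compound 3 `CCOC(=O)C1=Cc2ccccc2OC1(OCc1cn(CC(=O)Nc2ccc(OC)cc2)nn1)C(F)(F)F` gives 29400 nM in a functional assay on A549 cells (Homo sapiens) for inhibition, read by MTT assay, with a stated time of 24 h (a higher number here means a weaker inhibitor, a lower number a stronger inhibitor), the highest of the two numbers in hand. Compound 1 `CCOC(=O)C1=Cc2ccccc2OC1(OCc1cn(-c2ccc(F)cc2)nn1)C(F)(F)F` gives 7300 nM in this assay. For compound 2 `CCOC(=O)C1=Cc2ccccc2OC1(OCc1cc(-c2ccc(C)cc2)no1)C(F)(F)F` this assay reports only a limit, > 150000 nM. Going by the values given here, the single measured step, a 4.0-fold higher number from compound 1 to compound 3 (0.61 log units; beyond the scatter), is the one that bears here. Compound 4 `CCOC(=O)C1=Cc2ccccc2OC1(OCc1cn(-c2ccc(F)c(Cl)c2)nn1)C(F)(F)F` carries 3-chloro-4-fluorophenyl in place of ((4-methoxyphenyl)carbamoyl)methyl on an aromatic nitrogen, which largely reverses that change while adding a chlorine to the entering ring. A lower number, of about the size seen in the step of a 4.0-fold higher number from compound 1 to compound 3 (0.61 log units; beyond the scatter), is therefore expected. Compound 4 is expected to give 6500 nM in this assay, with a range from 2000 nM to 20000 nM. The expected step of a 4.5-fold lower number from compound 3 to compound 4 (0.66 log units; beyond the scatter) would roughly return to the level of compound 1.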

Compound 4, half-maximal inhibitory concentration: 26300 nM
The estimate for compound 4 lay 4.0-fold (0.61 log units) below the measured number, and the stated range ends below it.
By their numbers in this assay, from the lowest: compound 1; then compounds 4 and 3 (each within the scatter of the next). At a limit, above all of these: compound 2.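

On the aromatic nitrogen, a haloaryl group in place of the amide arm did not bring back the level of compound 1, with a 1.1-fold lower number from compound 3 to compound 4 (0.05 log units; within the scatter). The chloro in place of hydrogen on an aromatic carbon is the change that counts here, giving a 3.6-fold higher number from compound 1 to compound 4 (0.56 log units; beyond the scatter) in this assay, so a single added chlorine on the aryl ring was enough to leave compound 4 within the scatter of compound 3. No measurement shown accounts for this. Open, on these data alone, is whether a bromine or a nitrile at that ring carbon would act as chlorine does, or whether the chloro effect holds only alongside the 4-fluoro group.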